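Dienone series with coumarin-triazole tails: growth inhibition notes

The compounds below may be only part of what the source reports. "The series", "measured", "known", "first", "only" and "open" are said of these compounds alone.

Measured so far:
compound 1 `COc1ccccc1/C=C/C(=O)/C=C/c1ccc(OCc2cn(CCCOc3cc(=O)oc4ccccc34)nn2)c(OC)c1` — "not active" (no number reported)
compound 2 `COc1cc(/C=C/C(=O)/C=C/c2ccco2)ccc1OCc1cn(CCCCCOc2cc(=O)oc3ccccc23)nn1` — "not active" (no number reported)
compound 3 `COc1cc(/C=C/C(=O)/C=C/c2cccc3ccccc23)ccc1OCc1cn(CCOc2cc(=O)oc3ccccc23)nn1` — 20%

In a functional assay on PC-3 cells (Homo sapiens) for inhibition, read by sulforhodamine B assay, with a stated time of 48 h, tested at 50 uM (on this read-out higher numbers stand for more inhibition of growth at the one concentration tested and lower numbers for less inhibition of growth), compound 2 is reported as "not active" (no number reported) with no number attached, so it has no place on the numerical scale. Compound 1 is in the same situation, being reported in this assay as "not active" (no number reported). Only compound 3 carries a figure: in this assay compound 3 gives 20%. The series therefore has a single numerical anchor, and nothing in it reaches a large reading.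

Compound 4 `COc1ccc(/C=C/C(=O)/C=C/c2ccc(OCc3cn(CCCCCOc4cc(=O)oc5ccccc45)nn3)c(OC)c2)cc1OC` has not been measured. Compared with compound 2 the change is 3,4-dimethoxyphenyl in place of furan-2-yl on a double-bonded chain carbon bound to a double-bonded chain carbon. For the measured compounds named here, no measured pair shows this change, and compound 2 itself has no number, so the size of the step cannot be taken from the data. The expectation for compound 4 in this assay is shaped only by compound 3 at 20% and by the absence of activity for compound 2 and compound 1: a small reading, of the same order as compound 3, with a fair chance that again only "not active" is reported. Compound 4 is estimated at 15%, expected within 0% to 35%.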

Compound 4, percent growth inhibition at one concentration: "not active" (no number reported)
Compound 4 has no reported number here; the estimate stays without a comparison.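

In this assay compound 2 gives "not active" (no number reported) and compound 4 gives "not active" (no number reported) as well, so no step can be read between these two compounds. The compounds shown leave open whether 3,4-dimethoxyphenyl in place of furan-2-yl alters growth inhibition at all. No available evidence bears on these results.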